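Adding a 4-chlorophenyl group to a bare ring carbon

A few compounds are considered here, and "the series" means these few. Any claim that something is new, unique, unknown or untested is made for them only; others in the source may bear on it.

The measured compounds and their values:
Compound 1, `COc1ccc(-c2c(C#N)c(N)nc(SCc3csc(-c4ccc(I)cc4)n3)c2C#N)cc1`, gives 3.9 nM.
Compound 2, `COc1ccc(-c2c(C#N)c(N)nc(SCc3cscn3)c2C#N)cc1`, gives 1.3 nM.
Compound 3, `COc1ccc(-c2c(C#N)c(N)nc(SCc3nc(-c4ccc(Cl)cc4)sc3Br)c2C#N)cc1`, gives 162 nM.

These three compounds were tested in an assay on CHO cells for displacement of a labelled ligand from adenosine receptor A1 (Homo sapiens); on this read-out lower numbers stand for stronger inhibition and higher numbers for weaker inhibition. Compound 2 gives the lowest number of the three, with compound 1 nearest at a modestly higher value and compound 3 far above it.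

The unmeasured compound 4, `COc1ccc(-c2c(C#N)c(N)nc(SCc3csc(-c4ccc(Cl)cc4)n3)c2C#N)cc1`, differs from compound 2 in one place: 4-chlorophenyl in place of hydrogen on an aromatic carbon.

For the measured compounds named here, one measured step bears on this change. The step of a 3.0-fold lower number from compound 1 to compound 2 (0.48 log units; beyond the scatter) shows that removing a 4-iodophenyl from the same aromatic carbon lowered the number modestly. Compound 4 puts a related group, 4-chlorophenyl, back onto that carbon, so a modest rise of similar size is expected: a 2.7-fold higher number from compound 2 to compound 4 (0.43 log units; beyond the scatter). Compound 3 also carries a 4-chlorophenyl but differs in more than one place, so its value of 162 nM does not define this step.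

Compound 4 is therefore estimated at 3.5 nM, in a range from 1.2 nM to 10 nM.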

Compound 4, inhibition constant: 5 nM
Compound 4: middle estimate off by 1.4-fold (0.15 log units), on the low side, within the range that was stated.
By their numbers in this assay, from the lowest: compound 2; then compounds 1 and 4 (each within the scatter of the next); then compound 3.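

In this assay, putting 4-chlorophenyl on this ring carbon gives a 3.8-fold higher number from compound 2 to compound 4 (0.59 log units; beyond the scatter) and so moves the number the same way as the 4-iodophenyl of compound 1, which confirms that a large aryl group here gives a modestly weaker result than bare hydrogen. The halogen on that phenyl ring shows no readable effect, since chloro in place of iodo gives a 1.3-fold higher number from compound 1 to compound 4 (0.11 log units; within the scatter) and stays within the usual scatter. A different carbon of the same ring shows a far bigger step: with the 4-chlorophenyl kept, hydrogen in place of bromo gives a 32-fold lower number from compound 3 to compound 4 (1.51 log units; beyond the scatter) as a large change.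

On these data alone, whether a small methyl or an amine on the first carbon would stay as close to compound 2 remains open. Nothing available here explains why any of these steps has its size.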